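Benzyloxy extension of the ethoxy anilide benzoic acid

The compounds below may be only part of what the source reports. "The series", "measured", "known", "first", "only" and "open" are said of these compounds alone.

Measured so far:
compound 1 `CCOc1cccc(C(=O)Nc2cccc(C(=O)O)c2)c1`, 2350 nM
compound 2 `CCCCOc1ccc(C(=O)Nc2cccc(C(=O)O)c2)cc1`, 105 nM

In an assay on isolated protein for agonist activity at Bile acid receptor (Homo sapiens), read by TR-FRET, with a stated time of 3 h, in the absence of a further agent (a lower number here means that less compound is needed, a higher number that more compound is needed for the effect), compound 1 gives 2350 nM, the highest of the two numbers; compound 2 gives 105 nM, a lower number by a margin beyond the scatter. Compound 3 `Cc1cccc(COc2cccc(C(=O)Nc3cccc(C(=O)O)c3)c2)c1` is not yet measured. It differs from compound 1 by 3-methylphenyl in place of methyl on a saturated chain carbon bound to an oxygen on an aromatic ring. Among the compounds with values here, no step between measured compounds covers this change. A decrease is expected because compound 2 gives 105 nM with a larger group in place of ethoxy. The step from compound 1 to compound 3 is expected to be a 7.8-fold lower number from compound 1 to compound 3 (0.89 log units; beyond the scatter). Compound 3 is estimated at 300 nM, range 50 nM to 1800 nM.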

Compound 3, half-maximal effective concentration: 1860 nM
Beside the measured number, compound 3's estimate is 6.2-fold (0.79 log units) below it; measured number outside the range, above it.
By their numbers in this assay, from the lowest: compound 2; then compounds 3 and 1 (each within the scatter of the next).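

In this assay, 3-methylphenyl in place of methyl on a saturated chain carbon bound to an oxygen on an aromatic ring brings no change beyond the scatter (a 1.3-fold lower number from compound 1 to compound 3 (0.10 log units; within the scatter)). This place therefore accepts the added six-membered aromatic ring with neither a clear gain nor a clear loss. No available evidence bears on this result.

Still open, going by these compounds, is whether an unsubstituted phenyl or a propyl chain in the same place would move the number. Also open, on these data alone, is whether chlorine in place of the methyl on the added ring would do so.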